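The source may report more compounds than this note shows. Statements on the series, on what has been measured and on what is new or still open speak of the compounds shown alone.

Compound 1 `O=C(NCc1ccc(S(=O)(=O)c2ccccc2)cc1)NCc1cccnc1` gives 610 nM in a functional assay on A2780 cells (Homo sapiens) for cytotoxicity, read by sulforhodamine B assay, with a stated time of 72 h; on this read-out higher numbers stand for weaker inhibition and lower numbers for stronger inhibition. Compound 2 `O=C(NCc1ccc(S(=O)(=O)c2ccccc2)cc1)N1CCc2ccncc2C1` reaches only a limit of the assay, > 2000 nM, in this assay. Compound 3 `O=C(NCc1ccc(S(=O)(=O)C2CCOCC2)cc1)N1Cc2ccncc2C1` gives 35 nM in this assay.

Among the numbers in hand, compound 3 stands lowest, and its nearest neighbour is compound 1, whose number is higher by a gap that lies beyond the usual scatter. The value of compound 2 is a limit of the assay and not a number, so it cannot be placed against compound 3 with the same confidence.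

Compound 4 `O=C(NCc1ccc(S(=O)(=O)N2CC3(CCOCC3)C2)cc1)N1Cc2ccncc2C1` keeps the core of compound 3 and differs from it at a single place: a group of 9 heavy atoms (7 carbon, 1 nitrogen, 1 oxygen; one four-membered non-aromatic ring with 1 hetero atom, one six-membered non-aromatic ring with 1 hetero atom) in place of a group of 6 heavy atoms (5 carbon, 1 oxygen; one six-membered non-aromatic ring with 1 hetero atom), on a sulfonyl sulfur. For the measured compounds named here, no measured pair traces a change of this kind, so no measured step can be read across to it. The account therefore rests on compound 3 alone. The step from compound 3 to compound 4 is expected to be small and, if anything, towards a somewhat higher number, a 1.7-fold higher number from compound 3 to compound 4 (0.23 log units; within the scatter). Compound 4 is accordingly estimated at 60 nM, with a range from 20 nM to 250 nM.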

Compound 4, half-maximal inhibitory concentration: 10 nM
Beside the measured number, compound 4's estimate is 6.0-fold (0.78 log units) above it, outside the stated range (below it).
By their numbers in this assay, from the lowest: compound 4; then compound 3; then compound 1. At a limit, above all of these: compound 2.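

The sulfonyl sulfur of this series, whose other neighbour is an aromatic carbon, had until now offered no single-place comparison; compound 4 supplies the first one. In this assay, replacing oxan-4-yl with the larger group bearing both a four-membered and a six-membered non-aromatic ring gives a 3.5-fold lower number from compound 3 to compound 4 (0.54 log units; beyond the scatter), so this place accepts a bigger group with two rings, and the number falls beyond the scatter rather than rising. Nothing measured here gives a cause for this step.

The compounds shown leave open whether the gain follows from the four-membered ring, from the added ring nitrogen or from the size of the group as a whole. As far as these compounds go, a plain morpholine or a dimethylamino group on the same sulfonyl sulfur would separate these readings, and whether the step carries over to a different core also remains open.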